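The compounds below may be only part of what the source reports. "The series", "measured", "known", "first", "only" and "open" are said of these compounds alone.

Within the data shown here, compound 2 `CN(CCN)Cc1ccc(-c2ccc(C(F)(F)F)cc2)o1` is one of two compounds measured in an assay on cells for inhibition of protein arginine N-methyltransferase 1 (Homo sapiens), read by scintillation counting, with stated times of 15 min and 60 min, tested at 9 uM; a higher number here means more inhibition at the concentration tested (going by the name of the read-out), a lower number less inhibition. In that assay compound 2 gives 37%, the higher of the two numbers shown, the other belonging to compound 1 `COC(=O)c1ccc(-c2ccc(CN(C)CCN)o2)cc1`, which in this assay gives 30%. The step of a number 7 percentage points higher from compound 1 to compound 2 (within the scatter), trifluoromethyl in place of methoxycarbonyl on an aromatic carbon, lies within the scatter, so the two compounds cannot be ordered by these numbers. Compound 3 `COc1ccc(-c2ccc(CN(C)CCN)o2)cc1` is not yet measured. It differs from compound 2 as follows: methoxy in place of trifluoromethyl on an aromatic carbon. Among the measured compounds shown here, only the step from compound 1 to compound 2 bears on this change, since it also exchanges the group on the same aromatic carbon, and that step was small. The change to methoxy is therefore expected to give no step beyond the scatter, the estimated step being a number 4 percentage points lower from compound 2 to compound 3 (within the scatter). In this assay compound 3 is expected to give 33%, within a range from 18% to 48%.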

Compound 3, a percentage reported as inhibition, at one concentration (the size of the read-out at that concentration, not a potency): 25%
Estimate against measurement, compound 3: 8 percentage points above; the range from low to high includes it.
By their numbers in this assay, from the lowest: compounds 3, 1 and 2 (each within the scatter of the next, the first and the last beyond it).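

In this assay, among these compounds, methoxy in place of trifluoromethyl gives a number 12 percentage points lower from compound 2 to compound 3 (beyond the scatter) and is the first exchange on this aromatic carbon, para to a large group, to go beyond the scatter. Methoxy in place of methoxycarbonyl gives a number 5 percentage points lower from compound 1 to compound 3 (within the scatter) and so cannot be read as a change, which leaves compound 1 unresolved from both of the other compounds and makes trifluoromethyl and methoxy the only two groups here that can be ordered. Nothing measured here explains the modest step between these two groups.

The compounds shown leave open how an amine, a carboxylic acid or a nitrile on this same carbon would read in this assay against these three groups. They also leave open whether a longer chain in place of the amine side chain of the shared core would move the numbers at all.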